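The source may hold more compounds than are shown below. What is called first, only, known or untested is meant among the compounds shown, and "the series" means these compounds.

Compound 1 `O/N=C(\CCN1CCN(c2ccccn2)CC1)c1ccccc1Cl` gives 24 nM in a functional assay on HEK293 cells with D(4) dopamine receptor (Homo sapiens) as the target, read by FLIPR; a higher number here means that more compound is needed for the effect, a lower number that less compound is needed. Compound 2 `N#Cc1cccc(/C(CCN2CCN(c3ccccn3)CC2)=N/O)c1` gives 13.1 nM in this assay; the step of a 1.8-fold lower number from compound 1 to compound 2 (0.26 log units; within the scatter) lies within the scatter, so on these two numbers the pair stands together rather than apart. Compound 3 `O/N=C(\CCN1CCN(c2ccccn2)CC1)c1cc(F)cc(F)c1` differs from compound 2 by 3,5-difluorophenyl in place of 3-cyanophenyl on a carbon with a double bond to nitrogen. Going by the values given here, only the step of a 1.8-fold lower number from compound 1 to compound 2 (0.26 log units; within the scatter) bears on this change, as another exchange of the aryl on the same carbon, and it was within the scatter; no step beyond the scatter is expected in this assay. Compound 3 is therefore estimated at 18 nM, range 6 nM to 55 nM. The expected step is a 1.4-fold higher number from compound 2 to compound 3 (0.14 log units; within the scatter).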

Compound 3, half-maximal effective concentration: 19.4 nM
Beside the measured number, compound 3's estimate is 1.1-fold (0.03 log units) below it; the range from low to high includes it.
By their numbers in this assay, from the lowest: compounds 2, 3 and 1 (each within the scatter of the next).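

All three aryl groups on the carbon with a double bond to nitrogen now stand together in this assay: the exchange for 3,5-difluorophenyl gives a 1.5-fold higher number from compound 2 to compound 3 (0.17 log units; within the scatter) and a 1.2-fold lower number from compound 1 to compound 3 (0.09 log units; within the scatter). This holds although 3-cyanophenyl counts 1 hydrogen-bond acceptor and 3,5-difluorophenyl counts 0, so that difference brings no step beyond the scatter in these compounds. Nothing available explains why these exchanges stay within the scatter.

Going by these compounds, whether an aryl carrying an amine or a carboxylic acid would step beyond the scatter remains open. So does the effect of a longer chain on the shared core.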